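A few compounds are considered here, and "the series" means these few. Any claim that something is new, unique, unknown or untested is made for them only; others in the source may bear on it.

Compound 1 `COc1ccc(-c2cc3ccccc3c(-c3cccc(OC)c3)n2)cc1` and compound 2 `COc1ccc(-c2cc3ccccc3c(-c3cccc(N)c3)n2)cc1` share one core and differ in a single place: amino in place of methoxy on an aromatic carbon. In a functional assay on DU-145 cells (Homo sapiens) for cytotoxicity, read by CCK-8 assay and cell counting, with a stated time of 72 h (on this read-out lower numbers stand for stronger inhibition and higher numbers for weaker inhibition), compound 1 reaches only a limit of the assay, > 50000 nM. In this assay compound 2 gives 8610 nM. The resulting step, an at least 5.8-fold lower number from compound 1 to compound 2 (0.76 log units; beyond the scatter), is known only as a bound because compound 1 sits at the limit of > 50000 nM in this assay, at which 2 of the 3 values shown sit. Compound 3 `COc1cc(OC)cc(-c2cc3ccccc3c(-c3cccc(OC)c3)n2)c1` carries a different core; how the two cores differ is not broken down here. In this assay compound 3 also shows only a limit, > 50000 nM. Compound 4 `COc1cc(OC)cc(-c2cc3ccccc3c(-c3cccc(N)c3)n2)c1` stands to compound 3 as compound 2 stands to compound 1: amino in place of methoxy on an aromatic carbon, the same change at the same place. The step of an at least 4.1-fold lower number from compound 3 to compound 4 (0.61 log units; beyond the scatter) is expected, resting on an at least 5.8-fold lower number from compound 1 to compound 2 (0.76 log units; beyond the scatter). Compound 4 is estimated at 12000 nM, between 4000 nM and 50000 nM.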

Compound 4, half-maximal inhibitory concentration: 13200 nM
Compound 4: the middle estimate sits 1.1-fold (0.04 log units) below what was measured; the range from low to high includes it.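

On the second core, amino in place of methoxy again gives a lower number in this assay, with an at least 3.7-fold lower number from compound 3 to compound 4 (0.57 log units; beyond the scatter). The change therefore goes the same way on both cores shown, but the sizes of the two steps cannot be compared: the same change on two cores in this assay, an at least 5.8-fold lower number (0.76 log units; beyond the scatter) from compound 1 to compound 2 and an at least 3.7-fold lower number (0.57 log units; beyond the scatter) from compound 3 to compound 4; the limit leaves it open whether they differ. Among these compounds, this rests on only two pairs and does not show that the change would carry to any further core, and neither step has an exact size, since both start from a limit: the limit of > 50000 nM in this assay, at which 2 of the 4 values shown sit.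

The compounds shown leave open how a hydroxyl, an amide or a carboxylic acid would read in place of the amino group. They also leave open what a longer chain on that nitrogen would do.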